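From acetyl to 4-methoxyphenyl: one change, one expectation

The source may hold more compounds than are shown below. What is called first, only, known or untested is meant among the compounds shown, and "the series" means these compounds.

Measured so far in a functional assay on PC-12 cells (Rattus norvegicus) for cytotoxicity, read by MTT assay, with stated times of 3 h and 2 h, tested at 50 uM; a lower number here means a weaker effect, a higher number a stronger effect of the compound at the concentration tested:
compound 1 `O=C(CCCCC1CCSS1)NCc1cn(CCCOc2ccc3cc(-c4ccc(Cl)c(Cl)c4)c(=O)oc3c2)nn1` gives 54.8%
compound 2 `O=C(CCCCC1CCSS1)NCc1cn(CCCCOc2ccc3cc(-c4ccc(Cl)c(Cl)c4)c(=O)oc3c2)nn1` gives 69.5%
compound 3 `CC(=O)c1cc2ccc(OCCCCCn3cc(CNC(=O)CCCCC4CCSS4)nn3)cc2oc1=O` gives 18.2%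

Compound 3 stands lowest of the three numbers; compound 1 lies above it beyond the scatter, and compound 2 lies further above still. Compound 4 `COc1ccc(-c2cc3ccc(OCCCCCn4cc(CNC(=O)CCCCC5CCSS5)nn4)cc3oc2=O)cc1` differs from compound 3 in one place: 4-methoxyphenyl in place of acetyl on an aromatic carbon. For the measured compounds named here, no step between measured compounds is known, so the size of this change can only be expected. In this assay compound 4 is expected to give a higher number than compound 3, since compound 1 gives 54.8% and compound 2 gives 69.5% while neither carries an acetyl. The step expected from compound 3 to compound 4 is a number 26.8 percentage points higher from compound 3 to compound 4 (beyond the scatter), a rise beyond the scatter. Compound 4 is estimated at 45%, between 25% and 65%.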

Compound 4, a percentage reported as activity, at one concentration (the size of the read-out at that concentration, not a potency): 52.8%
Beside the measured number, compound 4's estimate is 7.8 percentage points below it; low and high end bracket the measured number.
By their numbers in this assay, from the lowest: compound 3; then compounds 4 and 1 (each within the scatter of the next); then compound 2.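

In this assay, a single exchange on this aromatic carbon, two atoms from the ring oxygen, gives a number 34.6 percentage points higher from compound 3 to compound 4 (beyond the scatter) with the rest of the molecule unchanged. For the compounds shown here, compounds 1 and 2 differ from compound 3 in more than one place, so only this pair shows that the position alone can shift the read-out so strongly. Nothing available bears on why the exchange has this effect. From the compounds shown here alone, whether a plain phenyl, an amine or a carboxylic acid on this carbon would give a similar number stays open, and so does whether the step would hold with a shorter chain.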